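Working notes: carbonyl aryl change from compound 1 to compound 4

A few compounds are considered here, and "the series" means these few. Any claim that something is new, unique, unknown or untested is made for them only; others in the source may bear on it.

Compound 1 `COc1cc(-c2cc(/C=C/C(=O)c3ccc(N)cc3)[nH]n2)cc(OC)c1OC` in a functional assay on HCT-116 cells (Homo sapiens) for cytotoxicity, read by sulforhodamine B assay, with a stated time of 48 h, tested at 0.01 uM (on this read-out higher numbers stand for a weaker effect at the one concentration tested and lower numbers for a stronger effect), gives 95%. Compound 2 `COc1ccc(-c2cc(/C=C/C(=O)c3ccc(N)cc3)[nH]n2)cc1OC` gives 96%, and compound 3 `COc1ccc(-c2cc(/C=C/C(=O)c3cc(OC)c(OC)c(OC)c3)[nH]n2)cc1OC` gives 100%. Compound 1 stands lowest of the three numbers, yet each gap is within the scatter, so it is not set apart from compound 2 or compound 3. Among the compounds with values here, the only single-point step recorded, a number 1 percentage points higher from compound 1 to compound 2 (within the scatter), came from hydrogen in place of methoxy on an aromatic carbon. Compound 4 `COc1ccc(C(=O)/C=C/c2cc(-c3cc(OC)c(OC)c(OC)c3)n[nH]2)cc1OC` differs from compound 1 by 3,4-dimethoxyphenyl in place of 4-aminophenyl on a carbonyl carbon. Within the data shown here, no measured step touches this place; compound 3 also differs at the carbonyl carbon, and in this assay compound 3 gives 100%. The step of a number 2 percentage points higher from compound 1 to compound 4 (within the scatter) is expected to stay within the scatter. Compound 4 is therefore estimated at 97%, between 88% and 104%.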

Compound 4, a percentage reported as activity, at one concentration (the size of the read-out at that concentration, not a potency): 99%
Beside the measured number, compound 4's estimate is 2 percentage points below it, within the range that was stated.
By their numbers in this assay, from the lowest: compounds 1, 2, 4 and 3 (each within the scatter of the next).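

Within this assay the step at the carbonyl carbon, 3,4-dimethoxyphenyl in place of 4-aminophenyl, is a number 4 percentage points higher from compound 1 to compound 4 (within the scatter) and is the only step shown at this place. At the one concentration tested, the two groups are therefore not told apart, even though the entering group lacks the nitrogen of the leaving one. No measurement on hand explains this result.

On these data alone, whether a carboxylic acid or a 4-hydroxyphenyl group on this carbonyl carbon would move the number beyond the scatter remains open. So does whether 4-aminophenyl and 3,4-dimethoxyphenyl would separate at another concentration.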